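A Chloro Step at the Limit of Tolerance

The compounds below may be only part of what the source reports. "The series", "measured", "known", "first", "only" and "open" are said of these compounds alone.

In an ADME assay on C2C12 cells (Mus musculus) for cytotoxicity (a higher number here means that more compound is tolerated, a lower number that less compound is tolerated), compound 3 (`c1ccc(CNc2ccnc(Nc3ccccc3)n2)cc1`) gives > 10000 nM, a limit of the assay and not a number. Compound 1 (`c1ccc(CNc2nc(Nc3ccccn3)nc3ccccc23)cc1`) gives > 10000 nM, also a limit. Compound 2 (`OCCCNc1nc(Nc2ccc(Cl)cc2)nc2ccccc12`) gives > 10000 nM, again a limit. Compound 3 therefore stands at the limit of > 10000 nM in this assay, at which 3 of the 3 values shown sit, and no measured step can be read from these data.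

Compound 4 (`Clc1ccc(Nc2nccc(NCc3ccccc3)n2)cc1`) differs from compound 3 by a single change, phenyl to 4-chlorophenyl, with chloro in place of hydrogen on an aromatic carbon. The 4-chlorophenyl group is already present in compound 2, whose reading of > 10000 nM is a limit. On that basis, no change beyond the usual scatter is expected in this assay, and neither direction is favoured. The expected shift a step that the limit leaves unreadable from compound 3 to compound 4 is estimated to remain within that scatter, and a further limit is the likeliest report. For compound 4, the estimated half-maximal cytotoxic concentration is 12000 nM, with an expected range of 5000 nM to 30000 nM.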

Compound 4, half-maximal cytotoxic concentration: > 10000 nM
Compound 4 gave a limit, no number (the forecaster's own chance of this, stated with the estimate: 70%); the middle value does not contradict the limit.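

Compound 3 and compound 4 each give a limit of the assay and not a number, and no step can be read between them. The compounds shown leave open the actual half-maximal cytotoxic concentration of each, and whether chloro in place of hydrogen changes it at all.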